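Fluorine on the aryl rings of a thiazole acetic acid series

The source may report more compounds than this note shows. Statements on the series, on what has been measured and on what is new or still open speak of the compounds shown alone.

Measured so far:
compound 1, `O=C(O)Cc1sc(C(c2ccccc2)c2ccccc2)nc1-c1ccc(F)cc1`, 80%
compound 2, `O=C(O)Cc1sc(C(c2ccc(F)cc2)c2ccc(F)cc2)nc1-c1ccc(Cl)cc1`, 80%
compound 3, `O=C(O)Cc1sc(C(c2ccccc2)c2ccc(F)cc2)nc1-c1ccc(Cl)cc1`, 80%

In an in vitro functional assay on HEK285-7 cells for antagonist activity at prostaglandin D2 receptor 2 (Homo sapiens), read by BRET and beta-arrestin recruitment (on this read-out higher numbers stand for larger maximal responses and lower numbers for smaller maximal responses), compound 3 gives 80%. The change fluoro in place of hydrogen on an aromatic carbon gives no change at the digits printed from compound 3 to compound 2 (within the scatter). The difference between the core of compound 1 and the core of compound 3 is not broken down here; in this assay compound 1 gives 80%, level with compounds 2 and 3.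

Compound 4, `O=C(O)Cc1sc(C(c2ccccc2)c2ccccc2)nc1-c1ccc(F)c(F)c1`, has not yet been measured. It differs from compound 1 by fluoro in place of hydrogen on an aromatic carbon. This is the same kind of change as that from compound 3 to compound 2, but the place differs: here the entering group sits ortho to a fluoro group and meta to a large group, whereas in the measured pair it sits para to a large group. Because no change at the digits printed from compound 3 to compound 2 (within the scatter), the step of no change at the digits printed from compound 1 to compound 4 (within the scatter) is expected to be small. Compound 4 is expected to reach about 80% in this assay, between 65% and 95%.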

Compound 4, largest response reached (reported as efficacy), in percent of the reference or control that the assay uses: 80%
The estimate for compound 4 equals the measured number at the digits printed; measured number inside the range.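

In this assay, fluoro in place of hydrogen on an aromatic carbon gives no change at the digits printed from compound 1 to compound 4 (within the scatter). Set beside the earlier step, the change carries from one core to the other without a detectable difference: the same change on two cores in this assay, no change at the digits printed (within the scatter) from compound 3 to compound 2 and no change at the digits printed (within the scatter) from compound 1 to compound 4, 0 percentage points apart, within the scatter of two such steps. This shows only that, on these two cores and at these two places, the change leaves the maximal response level; it does not show that the same would hold on other cores or at other places on the rings.

The compounds shown leave open whether any change on these aryl rings moves this response. As far as these compounds go, an amine or a trifluoromethyl group on the rings, or a longer chain in place of the acetic acid, remains untested here.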